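A few compounds are considered here, and "the series" means these few. Any claim that something is new, unique, unknown or untested is made for them only; others in the source may bear on it.

Measured compounds:
compound 1 `O=C(CCSC(=S)NCc1cccnc1)NCc1ccccc1`: > 100000 nM
compound 2 `S=C(NCc1cccnc1)SCCc1nnc(-c2ccccc2)o1`: 2770 nM

Of the compounds shown here, two have been tested in a functional assay on MDA-MB-468 cells (Homo sapiens) for cytotoxicity, read by resazurin assay, with a stated time of 72 h; on this read-out higher numbers stand for weaker inhibition and lower numbers for stronger inhibition. Compound 1 `O=C(CCSC(=S)NCc1cccnc1)NCc1ccccc1` gives > 100000 nM in this assay, which is a limit of the assay and not a number. Among the compounds with values here, compound 2 `S=C(NCc1cccnc1)SCCc1nnc(-c2ccccc2)o1` is the only compound with a numerical result, giving 2770 nM in this assay. Compound 3 `Fc1ccccc1-c1nnc(CCSC(=S)NCc2cccnc2)o1` has not yet been measured. It differs from compound 2 in one place: fluoro in place of hydrogen on an aromatic carbon. Within the data shown here, no pair of measured compounds differs in just one place, so there is no measured step to compare this change with. Such a swap of hydrogen for fluoro on a phenyl is expected to shift the result little, so the step of a 1.1-fold lower number from compound 2 to compound 3 (0.04 log units; within the scatter) that is expected is none beyond the usual scatter. Compound 3 is therefore expected to give about 2500 nM in this assay, most likely between 900 nM and 7000 nM.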

Compound 3, half-maximal inhibitory concentration: 3420 nM
The estimate for compound 3 lay 1.4-fold (0.14 log units) below the measured number, within the range that was stated.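

In this assay, within the data shown here, adding fluoro to the phenyl, ortho to a large group, gives a 1.2-fold higher number from compound 2 to compound 3 (0.09 log units; within the scatter), the first measured step between two compounds that differ in one place. On this evidence, phenyl and 2-fluorophenyl cannot be told apart in this cell assay, so this position accepts a single fluoro with no change that can be separated from ordinary repeat-to-repeat variation. Nothing shown here offers a reason for this result.

As far as these compounds go, what remains open is whether a different group at the same place, such as a methoxy, a trifluoromethyl or an amine, would move the number, and whether fluoro at other places on the phenyl would do so. Also open, from the compounds shown here alone, is whether a change elsewhere in the shared core, such as a longer chain in the linker, would have a clearer effect.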